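From 2,4-difluorophenyl to 4-hydroxyphenyl: a step away from a limit

A few compounds are considered here, and "the series" means these few. Any claim that something is new, unique, unknown or untested is made for them only; others in the source may bear on it.

Compound 1 `O=S(=O)(/C=C/c1ccccc1)Cc1ccc(Nc2ncnc3ccccc23)cc1` gives > 100000 nM as a limit
Compound 2 `O=S(=O)(/C=C/c1ccc(Cl)cc1Cl)Cc1ccc(Nc2ncnc3ccccc23)cc1` gives 24000 nM as a number
Compound 3 `O=S(=O)(/C=C/c1ccc(F)cc1F)Cc1ccc(Nc2ncnc3ccccc23)cc1` gives > 100000 nM as a limit
Compound 4 `O=S(=O)(/C=C/c1ccc(O)cc1)Cc1ccc(Nc2ncnc3ccccc23)cc1` has no value yet

All of these values come from a functional assay on HT-29 cells (Homo sapiens) (on this read-out lower numbers stand for stronger inhibition of growth and higher numbers for weaker inhibition of growth), and only one of them is a number. Compound 3 stands at > 100000 nM in that read-out, and this is a limit, not a number. Compound 1 reads > 100000 nM and this too is a limit.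

The change now followed is 4-hydroxyphenyl in place of 2,4-difluorophenyl on a double-bonded chain carbon bound to a double-bonded chain carbon and it places 4-hydroxyphenyl where 2,4-difluorophenyl stood, on a double-bonded chain carbon bound to a double-bonded chain carbon. Three measured steps at this place bear on it. Two are readable, namely an at least 4.1-fold lower number from compound 1 to compound 2 (0.61 log units; beyond the scatter) and an at least 4.1-fold higher number from compound 2 to compound 3 (0.61 log units; beyond the scatter) as well. The third, a step that the two limits leave unreadable from compound 1 to compound 3 as it stands, gives no size. None of them involves 4-hydroxyphenyl, so they offer only a loose guide. Compound 2 at 24000 nM is the only one that reads as a number, so a large gain is not expected. Compound 4 may well stay at the limit too. The expected change is an at least 1.6-fold lower number from compound 3 to compound 4 (0.22 log units; that floor lies within the scatter) and it is estimated to stay modest. In this assay the estimate for compound 4 is 60000 nM with an expected range between 20000 nM and 150000 nM for repeat measurements.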

Compound 4, concentration for 50% growth inhibition: 2000 nM
Estimate against measurement, compound 4: 30-fold (1.48 log units) above, outside the stated range (below it).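

In this assay, going by these compounds alone, hydroxy in place of hydrogen on an aromatic carbon brings an at least 50-fold lower number from compound 1 to compound 4 (1.69 log units; beyond the scatter), which shows that a single added group on the phenyl ring can produce a large step at this position. 4-Hydroxyphenyl also outperforms both disubstituted groups, with a 12-fold lower number from compound 2 to compound 4 (1.08 log units; beyond the scatter) and an at least 50-fold lower number from compound 3 to compound 4 (1.69 log units; beyond the scatter), so 2,4-dichlorophenyl no longer stands as the only group here that gives a readable value. The steps from compound 1 and from compound 3 each start from a limit, so they give a floor and not a full size: the limit of > 100000 nM in this assay, at which 2 of the 4 values shown sit.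

The compounds shown leave open whether the large step is specific to hydroxy, since they do not tell how a methoxy, an amine or a carboxylic acid in the same place on the phenyl ring would read. They also leave open whether hydroxy keeps this effect when it is combined with chloro or fluoro on the same ring, or when the double-bonded chain carrying the ring is replaced by a longer chain.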